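Removing the fluorine-bearing aryl pattern of compound 3

This account rests on a few compounds, and the source may have more. Where it says the series, first, only, none or still open, it means among the compounds named here.

Of the compounds shown here, three sharing one core have been tested in a functional assay on MCF-A cells (Homo sapiens) for cytotoxicity (on this read-out higher numbers stand for weaker inhibition of growth and lower numbers for stronger inhibition of growth), so far. Compound 1 `COc1ccc(C2=C(c3cc(OC)c(OC)c(OC)c3)CC3CCCN3C2=O)cc1O` gives > 100000 nM as a limit of the assay and not a number. Compound 2 `COc1ccc(C2=C(c3ccc(SC)cc3)CC3CCCN3C2=O)cc1OC(=O)CNC(=O)OC(C)(C)C` reads 6000 nM in this assay and compound 3 `CSc1ccc(C2=C(c3ccc(F)c(C)c3)C(=O)N3CCCC3C2)cc1` reads 500 nM as the lower of the two true numbers, a gap beyond the scatter.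

Compound 4 `CSc1ccc(C2=C(c3ccc(C)cc3)C(=O)N3CCCC3C2)cc1` carries a single change from compound 3: 4-methylphenyl in place of 4-fluoro-3-methylphenyl on a double-bonded ring carbon on a double-bonded ring carbon. Within the data shown here, no measured pair here tests such a swap, so the expectation stays cautious. The expected step is a 1.6-fold higher number from compound 3 to compound 4 (0.20 log units; within the scatter) as a small rise in the number, close to the scatter. In this assay compound 4 is estimated at 800 nM with an expected range of 200 nM to 3000 nM for its measurement.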

Compound 4, concentration for 50% growth inhibition: 600 nM
Estimate against measurement, compound 4: 1.3-fold (0.12 log units) above; measured number inside the range.
By their numbers in this assay, from the lowest: compounds 3 and 4 (each within the scatter of the next); then compound 2. At a limit, above all of these: compound 1.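

In this assay, the first direct test of this position shows a 1.2-fold higher number from compound 3 to compound 4 (0.08 log units; within the scatter), with 4-methylphenyl in place of 4-fluoro-3-methylphenyl on the double-bonded ring carbon. In this pair, the fluorine-bearing pattern is therefore not needed to keep the reading in the same range. Nothing measured here bears on why the two compounds read alike.

Going by these compounds, it remains open how 4-fluorophenyl would read at this position. A phenyl ring carrying an amine or a carboxylic acid in place of the methyl also remains untested among the compounds shown.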